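Bromo substitution on a weaker pyrazoline-oxindole analogue

The source may report more compounds than this note shows. Statements on the series, on what has been measured and on what is new or still open speak of the compounds shown alone.

In a functional assay on cells (Melanoma cell, Homo sapiens) for cytotoxicity, read by sulforhodamine B assay, with a stated time of 48 h (a lower number here means a stronger inhibitor of growth, a higher number a weaker inhibitor of growth), three compounds have been measured:
compound 1, `O=C1N=C(N2N=C(c3ccccc3)CC2c2ccccc2O)S/C1=C1/C(=O)Nc2ccccc21`, gives 2040 nM;
compound 2, `O=C1N=C(N2N=C(c3ccccc3)CC2c2ccccc2O)S/C1=C1/C(=O)Nc2ccc(Br)cc21`, gives 230 nM;
compound 3, `COc1ccc(C2=NN(C3=NC(=O)/C(=C4\C(=O)Nc5ccccc54)S3)C(c3ccc(OC)cc3)C2)cc1`, gives 100000 nM.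

Compound 1 and compound 2 share one core and differ by bromo in place of hydrogen on an aromatic carbon; this change produced an 8.9-fold lower number from compound 1 to compound 2 (0.95 log units; beyond the scatter). Compound 3 carries a different core, and the difference between the two cores is not broken down here; its value is the highest of the three. Compound 4, `COc1ccc(C2=NN(C3=NC(=O)/C(=C4\C(=O)Nc5ccc(Br)cc54)S3)C(c3ccc(OC)cc3)C2)cc1`, has not yet been measured. It differs from compound 3 by bromo in place of hydrogen on an aromatic carbon, the same change as that from compound 1 to compound 2. The expectation for compound 4 rests on that earlier step, an 8.9-fold lower number from compound 1 to compound 2 (0.95 log units; beyond the scatter). For compound 4 the expected step is a 6.7-fold lower number from compound 3 to compound 4 (0.82 log units; beyond the scatter), with wide uncertainty. Compound 4 is therefore estimated at 15000 nM, likely between 3000 nM and 100000 nM.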

Compound 4, concentration for 50% growth inhibition: 190 nM
Compound 4: the middle estimate sits 79-fold (1.90 log units) above what was measured; the whole stated range lies above it.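

In this assay, bromo in place of hydrogen on an aromatic carbon gave a 530-fold lower number from compound 3 to compound 4 (2.72 log units; beyond the scatter), so the number fell on both cores, but by very different amounts: the same change on two cores in this assay, an 8.9-fold lower number (0.95 log units; beyond the scatter) from compound 1 to compound 2 and a 530-fold lower number (2.72 log units; beyond the scatter) from compound 3 to compound 4, 59-fold (1.77 log units) apart, beyond the scatter of two such steps The direction of the step therefore carried from one core to the other, while its size did not, so a step measured on one core was a poor guide to its size on the other. Within the data shown here, with only two pairs, this does not show why the sizes differ or how the change would behave on a third core.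

The compounds shown leave open which of the differences between the two cores accounts for the gap. They also leave open whether chloro or an amine on the same aromatic carbon would follow bromo.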